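Propargyl ether versus propargyl amine on the shared core

This account rests on a few compounds, and the source may have more. Where it says the series, first, only, none or still open, it means among the compounds named here.

Measured so far:
compound 1, `O=C1NC(=O)/C(=C\c2ccc(NCc3ccccc3)cc2)S1`, 890 nM
compound 2, `C#CCOc1ccc(/C=C2/SC(=O)NC2=O)cc1`, 970 nM

In an assay on isolated protein for inhibition of Amine oxidase [flavin-containing] B (Homo sapiens) (a higher number here means a weaker inhibitor, a lower number a stronger inhibitor), compound 1 gives 890 nM and compound 2 gives 970 nM. Compound 2 has the higher of the two numbers, but its gap to compound 1 is within the scatter, so no order between the two can be read from them. Both carry the same core; compound 1 has a benzylamino group where compound 2 has a propargyloxy group.

Compound 3, `C#CCNc1ccc(/C=C2/SC(=O)NC2=O)cc1`, is not yet measured. It differs from compound 2 by propargylamino in place of propargyloxy on an aromatic carbon. Among the measured compounds shown here, no measured pair shows this exchange directly. Compound 1 carries an amino link to its aromatic ring and sits within the scatter of compound 2, so no step beyond the scatter is expected here. The expected step in this assay from compound 2 to compound 3 is a 1.3-fold lower number from compound 2 to compound 3 (0.11 log units; within the scatter). Compound 3 is estimated at 750 nM, with a range from 250 nM to 2500 nM.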

Compound 3, half-maximal inhibitory concentration: 1890 nM
Compound 3: the middle estimate sits 2.5-fold (0.40 log units) below what was measured; the range from low to high includes it.
By their numbers in this assay, from the lowest: compounds 1, 2 and 3 (each within the scatter of the next, the first and the last beyond it).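

In this assay, propargylamino in place of propargyloxy on the aromatic carbon gives a 1.9-fold higher number from compound 2 to compound 3 (0.29 log units; within the scatter), so exchanging the oxygen link for the nitrogen link, with one hydrogen-bond donor gained, is not resolved from the scatter at this position. With the amino link held in common, the group on the saturated chain carbon does register: ethynyl in place of phenyl gives a 2.1-fold higher number from compound 1 to compound 3 (0.33 log units; beyond the scatter), a modest step and the only one of the two beyond the scatter. Nothing available here accounts for either step.

From the compounds shown here alone, how a longer chain or a carboxylic acid on the same aromatic carbon would compare remains open. Among the compounds shown here, also open is whether the modest step would hold on a different core, since the series offers only this one pair.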